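The source may report more compounds than this note shows. Statements on the series, on what has been measured and on what is new or still open speak of the compounds shown alone.

Measured so far in an assay on isolated protein for inhibition of thyroid hormone receptor beta (Homo sapiens), read by fluorescence polarization; a higher number here means a weaker inhibitor, a lower number a stronger inhibitor:
Compound 1 `CS(=O)(=O)c1ccc(C(=O)N2CCC(C(=O)N3CCN(c4ccc(F)cc4)CC3)CC2)cc1[N+](=O)[O-]` gives > 60000 nM, which is a limit of the assay.
Compound 2 `CS(=O)(=O)c1ccc(C(=O)NCC(=O)N(Cc2ccccc2)Cc2ccccc2)cc1[N+](=O)[O-]` gives 3600 nM.
Compound 3 `CCCN(C(=O)CN(C)C(=O)c1ccc(S(C)(=O)=O)c([N+](=O)[O-])c1)c1ccccc1` gives > 60000 nM, which is a limit of the assay.

Among these three, compound 2 holds the only number; the other two values are limits. Among the measured compounds shown here, compound 1 and compound 3 sit at the limit of > 60000 nM in this assay, at which 2 of the 3 values shown sit, so compound 2 is the one measured compound whose half-maximal inhibitory concentration can be compared as a number.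

Compound 4 `CN(CC(=O)N(Cc1ccccc1)Cc1ccccc1)C(=O)c1ccc(S(C)(=O)=O)c([N+](=O)[O-])c1` has not yet been measured. It differs from compound 2 in one place: methyl in place of hydrogen on an amide-type nitrogen. For the measured compounds named here, no pair of measured compounds differs by exactly this change, so the size of the step is not fixed by the data. Compound 3 carries the same methyl on its amide-type nitrogen but a different amine portion, and it sits at a limit while compound 2 gives a number; the two structures differ in more than the methyl, so this does not isolate the change. The step from compound 2 to compound 4 is expected to be a 2.5-fold higher number from compound 2 to compound 4 (0.40 log units; beyond the scatter), a weakening of moderate size, with a fair chance that only a limit results. Compound 4 is therefore estimated at 9000 nM, within the range 2500 nM to 40000 nM in this assay.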

Compound 4, half-maximal inhibitory concentration: > 60000 nM
Compound 4: only a limit was reported; the forecaster's own chance of this, stated with the estimate: 25%; at least 6.6-fold (0.82 log units) between middle value and limit.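

In this assay compound 4 gives > 60000 nM, which is a limit of the assay. This gives the first pair among the compounds shown that differs in one place, and putting methyl in place of hydrogen on the amide-type nitrogen, whose other neighbours are a carbonyl carbon and a saturated chain carbon, gives an at least 16-fold higher number from compound 2 to compound 4 (1.22 log units; beyond the scatter), a large step that takes away the only measured number in the set. The step sets only a lower bound on the loss and not its full size, because compound 4 joins the other compounds at the limit: the limit of > 60000 nM in this assay, at which 3 of the 4 values shown sit.

As far as these compounds go, what an ethyl group or a longer chain on this same nitrogen would give remains open, and this single pair cannot show whether the loss comes with methyl alone or with any group that replaces the amide hydrogen. Also open, from the compounds shown here alone, is whether the hydrogen is needed with other amine portions, since the benzyl groups of compound 2 are the only setting in which the change can be read.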